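Working notes: aryl variation and cytotoxicity in the sulfonamide series

This account rests on a few compounds, and the source may have more. Where it says the series, first, only, none or still open, it means among the compounds named here.

Compound 1 `O=c1[nH]cc(S(=O)(=O)Nc2cccc(-c3cn(-c4ccccc4)nn3)c2)c(=O)[nH]1` and compound 2 `Cc1cccc(-n2cc(-c3cccc(NS(=O)(=O)c4c[nH]c(=O)[nH]c4=O)c3)nn2)c1` share the core of compound 1 and differ only in the substituent on the phenyl that sits on an aromatic nitrogen of a five-membered aromatic ring with 3 nitrogen. In an ADME assay on GES1 cells (Homo sapiens) for cytotoxicity, read by MTT assay, with a stated time of 24 h (on this read-out lower numbers stand for higher toxicity in this test and higher numbers for lower toxicity in this test), compound 1 gives 22500 nM and compound 2 gives 18500 nM; the step of a 1.2-fold lower number from compound 1 to compound 2 (0.09 log units; within the scatter) lies within the scatter, so the two stand together. Going by the values given here, compound 3 `Cc1ccc(-n2cc(-c3ccc(NS(=O)(=O)c4c[nH]c(=O)[nH]c4=O)cc3)nn2)cc1` is reported in this assay as "not toxic" (no number reported), without a single number, so it cannot be placed on the scale of compound 1 and compound 2 and no measured step leads to it.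

Compound 4 `O=c1[nH]cc(S(=O)(=O)Nc2ccc(-c3cn(-c4cccc(Cl)c4)nn3)cc2)c(=O)[nH]1` differs from compound 3 by 3-chlorophenyl in place of 4-methylphenyl on an aromatic nitrogen. Among the compounds with values here, the only measured step, a methyl in place of hydrogen on the same aryl group, was within the scatter; no measured step covers chlorine in place of methyl, so the expectation for compound 4 rests on the series as a whole, where every number stands at low toxicity and one member gave no number at all. No step beyond the scatter is expected, and a further limit-only outcome is possible. Compound 4 is estimated in this assay at 25000 nM, within 10000 nM to 60000 nM.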

Compound 4, half-maximal cytotoxic concentration: 7570 nM
Estimate against measurement, compound 4: 3.3-fold (0.52 log units) above, and the stated range ends above it.
By their numbers in this assay, from the lowest: compound 4; then compounds 2 and 1 (each within the scatter of the next).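

In this assay compound 4 gives 7570 nM, but compound 3 carries no number, so no step can be read from compound 3 to compound 4. The compounds shown leave open how 3-chlorophenyl in place of 4-methylphenyl on an aromatic nitrogen bears on this read-out. Nothing shown here offers an explanation for the value of compound 4.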